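The source may report more compounds than this note shows. Statements on the series, on what has been measured and on what is new or still open speak of the compounds shown alone.

Measured so far:
compound 1, `c1ccc(COc2nc3ccccc3s2)cc1`: 51.9%
compound 2, `FC(F)(F)c1ccc(COc2nc3ccccc3s2)cc1`: 99.6%

Among the compounds with values here, in a functional assay on the whole organism with Mus musculus as the target, in the writhing test, at a dose of 100 mg/kg by the intraperitoneal route (on this read-out lower numbers stand for less inhibition and higher numbers for more inhibition at the one dose given (going by the name of the read-out)), compound 2 gives the higher of the two numbers; the one step measured is a number 47.7 percentage points higher from compound 1 to compound 2 (beyond the scatter), a large change. Compound 3, `O=[N+]([O-])c1ccc(COc2nc3ccccc3s2)cc1`, is not yet measured. Its change from compound 2 is nitro in place of trifluoromethyl on an aromatic carbon. Within the data shown here, the step from compound 1 to compound 2 shows that the group on this aromatic carbon can move inhibition strongly, but no measured step compares nitro with trifluoromethyl, so the direction is uncertain. Because compound 2 gives 99.6%, a number near the top of the range, a fall is expected rather than a rise: a number 19.6 percentage points lower from compound 2 to compound 3 (beyond the scatter). Compound 3 is estimated at 80%, within 45% to 100%.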

Compound 3, a percentage reported as inhibition, in the whole organism at one dose (the size of the read-out at that dose, not a potency): 97%
Compound 3: the middle estimate sits 17 percentage points below what was measured; the range from low to high includes it.
By their numbers in this assay, from the lowest: compound 1; then compounds 3 and 2 (each within the scatter of the next).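

In this assay, swapping trifluoromethyl for nitro on this aromatic carbon, para to a large group, gives a number 2.6 percentage points lower from compound 2 to compound 3 (within the scatter), so the two groups cannot be told apart here. Nitro in place of hydrogen gives a number 45.1 percentage points higher from compound 1 to compound 3 (beyond the scatter), which shows that the large gain is not unique to trifluoromethyl. Nothing available explains why these two groups give such similar results.

As far as these compounds go, whether an amine or a methoxy group on this carbon would also raise the number remains open. From the compounds shown here alone, it is also open whether compound 2 and compound 3 would separate at a lower dose.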